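From a carboxylic acid to a morpholine amide

The compounds below may be only part of what the source reports. "The series", "measured", "known", "first", "only" and "open" are said of these compounds alone.

Measured in a functional assay on KB cells (Homo sapiens) for inhibition, read by sulforhodamine B assay, with a stated time of 72 h (a higher number here means a weaker inhibitor of growth, a lower number a stronger inhibitor of growth), so far:
- compound 1 `O=C(O)/C=C/c1ccncc1-c1ccc2cc[nH]c2c1`: > 10000 nM, a limit of the assay, not a number.
- compound 2 `COC1CN(C(=O)/C=C/c2ccncc2-c2ccc3ccccc3c2)C1`: > 10000 nM, also a limit.
- compound 3 `CNC(=O)/C=C/c1ccncc1-c1ccc2ccccc2c1`: > 10000 nM, also a limit.

Compound 1 stands at the limit of the assay, as do both other compounds; (the limit of > 10000 nM in this assay, at which 3 of the 3 values shown sit). Within the data shown here, the one step between measured compounds, a step that the two limits leave unreadable from compound 2 to compound 3, changes one amide substituent for another on the core of compound 2 and cannot be sized, since both ends are limits. Compound 4 `O=C(/C=C/c1ccncc1-c1ccc2cc[nH]c2c1)N1CCOCC1` differs from compound 1 in this way: morpholin-4-yl in place of hydroxy on a carbonyl carbon. Among the measured compounds shown here, no measured step bears directly on this change; the only related evidence is that the two amides, compound 2 and compound 3, both sit at the limit. For compound 4 the expected step that the limit leaves unreadable from compound 1 to compound 4 is therefore none beyond the scatter, with a limit the most likely outcome. The estimate for compound 4 is 20000 nM, within 5000 nM to 80000 nM.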

Compound 4, concentration for 50% growth inhibition: > 10000 nM
Compound 4: a limit, no number; the forecaster's own chance of this, stated with the estimate: 85%; the middle value does not contradict the limit.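

Among these compounds, compound 1 and compound 4 both give only a limit in this assay, not a number, so no step between them can be read. The compounds shown leave open how strongly any of them inhibits growth, and whether morpholin-4-yl in place of hydroxy changes that at all: the limit of > 10000 nM in this assay, at which 4 of the 4 values shown sit.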